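Flipping the Double Bond of Compound 2

The compounds below may be only part of what the source reports. "The series", "measured", "known", "first", "only" and "open" are said of these compounds alone.

Compound 1 `Fc1ccc(/C=C/c2cc(F)cc(F)c2)cc1`: 3.8 nM
Compound 2 `FC(F)(F)c1ccc(/C=C/c2cc(C(F)(F)F)cc(C(F)(F)F)c2)cc1`: 2.1 nM

In an assay on cytosol from liver for antagonist activity at aryl hydrocarbon receptor (Oryctolagus cuniculus) (on this read-out higher numbers stand for weaker inhibition and lower numbers for stronger inhibition), compound 1 gives 3.8 nM and compound 2 gives 2.1 nM. Compound 2 gives the lower of the two numbers, yet its gap to compound 1 lies within the scatter, so the two are not told apart. Compound 3 `FC(F)(F)c1ccc(/C=C\c2cc(C(F)(F)F)cc(C(F)(F)F)c2)cc1` is not yet measured. It differs from compound 2 as follows: the two compounds have the same atoms and bonds and differ only in configuration as drawn: 1 of 1 stereo elements differ; a double bond is drawn E in compound 2 and Z in compound 3. Going by the values given here, no measured pair shows what this change does. Compound 3 is expected to give a higher number, with the step of a 5.7-fold higher number from compound 2 to compound 3 (0.76 log units; beyond the scatter) reaching beyond the scatter. The estimate for compound 3 is 12 nM, within a range from 2.5 nM to 60 nM.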

Compound 3, inhibition constant: 60 nM
For compound 3 the middle estimate is 5.0-fold (0.70 log units) below the measured one; low and high end bracket the measured number.
By their numbers in this assay, from the lowest: compounds 2 and 1 (each within the scatter of the next); then compound 3.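

Compounds 1 and 2 both carry an E double bond, so they could not show whether its geometry matters. In this assay, turning it to Z gives a 29-fold higher number from compound 2 to compound 3 (1.46 log units; beyond the scatter), so inhibition here is clearly weaker in the Z form although no atom enters or leaves. The step can be assigned to the double bond alone because nothing else changes: the fact that compounds 2 and 3 differ only in the configuration as drawn.

The compounds shown leave open whether the Z form of compound 1 would lose as much. They also leave open whether an amine or a carboxylic acid in place of a trifluoromethyl group would keep the low numbers of the E compounds.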